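The compounds below may be only part of what the source reports. "The series", "measured", "known", "first", "only" and "open" are said of these compounds alone.

Two compounds built on the shared core, each carrying an acetic acid side chain on the thiazole, have been measured. In an in vitro functional assay on HEK285-7 cells for antagonist activity at prostaglandin D2 receptor 2 (Homo sapiens), read by BRET and beta-arrestin recruitment (a lower number here means a stronger inhibitor, a higher number a weaker inhibitor), compound 1 `O=C(O)Cc1sc(COc2ccc(Cl)cc2)nc1-c1ccc(Cl)cc1` gives 370 nM. In this assay compound 2 `O=C(O)Cc1sc(C(c2ccc(F)cc2)c2ccc(F)cc2)nc1-c1ccc(Cl)cc1` gives 180 nM, the lower of the two numbers; its nearest neighbour is compound 1, whose number lies higher by more than the usual scatter of repeated measurements, so compound 2 is the stronger inhibitor of the pair on this evidence.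

Compound 3 `NS(=O)(=O)c1ccc(-c2nc(C(c3ccc(F)cc3)c3ccc(F)cc3)sc2CC(=O)O)cc1` keeps the bis(4-fluorophenyl)methyl group of compound 2 and changes only the aryl ring on the other side of the core: sulfamoyl in place of chloro on an aromatic carbon. Going by the values given here, no pair of measured compounds shows this kind of exchange, so there is no measured step to lean on, and the expectation rests on the single value of compound 2 and the size of the change. The step of a 2.2-fold higher number from compound 2 to compound 3 (0.35 log units; beyond the scatter) is expected to be modest and toward a weaker inhibitor, though not far beyond the scatter. In this assay compound 3 is estimated at 400 nM, with a plausible range from 100 nM to 1500 nM.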

Compound 3, half-maximal inhibitory concentration: > 100000 nM
Compound 3 was reported as a limit; the forecaster's own chance of this, stated with the estimate: 10%; middle value at least 250-fold (2.39 log units) from the limit.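

Compounds 1 and 2 both carry the 4-chlorophenyl group, so they said nothing about how much this position tolerates; the exchange of 4-chlorophenyl to 4-sulfamoylphenyl, with the bis(4-fluorophenyl)methyl group unchanged, now shows that a single change here can nearly abolish the measurable response, giving an at least 550-fold higher number from compound 2 to compound 3 (2.74 log units; beyond the scatter). In this assay compound 3 gives > 100000 nM, which is a limit of the assay and not a number. The step therefore fixes only a minimum size for the change, and the true size stays unknown: the limit of > 100000 nM in this assay, at which 1 of the 3 values shown sits.

From the compounds shown here alone, whether a methylsulfonyl group, which keeps the sulfur and both oxygens of sulfamoyl but drops the nitrogen, or a smaller group such as a nitrile or a primary carboxamide at this place would hold the number near that of compound 2 remains open. Also open, going by these compounds, is whether 4-sulfamoylphenyl would cost as much alongside the substituent that compound 1 carries in place of bis(4-fluorophenyl)methyl.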